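A few compounds are considered here, and "the series" means these few. Any claim that something is new, unique, unknown or untested is made for them only; others in the source may bear on it.

Working notes on the step from compound 2 to compound 3.

Compound 2 `CCS(=O)(=O)Nc1cccc(NC2=NCCN2)c1` has only a limit in an assay on isolated protein (Cricetulus griseus) for binding affinity to Alpha-1B adrenergic receptor (Mesocricetus auratus), read by radioligand binding; a lower number here means a stronger inhibitor, a higher number a weaker inhibitor: compound 2 gives < 10000 nM, which is a limit of the measurement and not a number. The same holds for compound 1 `CN(c1cccc2c1CCCC2c1c[nH]cn1)S(C)(=O)=O`, for which compound 1 gives < 10000 nM in this assay, again a limit. Among the measured compounds shown here, both values therefore rest at the limit of < 10000 nM in this assay, at which 2 of the 2 values shown sit, so no step between measured compounds can be set out and nothing is known about where compound 2 falls beneath that limit.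

Compound 3 `CCS(=O)(=O)Nc1cccc(C2CCNC2)c1` differs from compound 2 by a group of 5 heavy atoms (4 carbon, 1 nitrogen; one five-membered non-aromatic ring with 1 hetero atom) in place of a group of 6 heavy atoms (3 carbon, 3 nitrogen; one five-membered non-aromatic ring with 2 hetero atoms), on an aromatic carbon, meta to a (ethylsulfonyl)amino group.

For the measured compounds named here, with no measured step to lean on, the expected step from compound 2 to compound 3 in this assay is a step that the limit leaves unreadable from compound 2 to compound 3, taken only as a rough guess and not beyond the scatter with any confidence. For compound 3 the expected value in this assay is estimated at 3000 nM, with a range from 300 nM to 10000 nM, and a real chance that the measurement again returns only a limit.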

Compound 3, inhibition constant: < 10000 nM
Compound 3 ended at the assay's limit (the forecaster's own chance of this, stated with the estimate: 50%); the middle value lies beyond the limit too.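

Compound 3 gives < 10000 nM in this assay, which is a limit and not a number. No step from compound 2 to compound 3 can be read, as both values are limits: the limit of < 10000 nM in this assay, at which 3 of the 3 values shown sit.

The compounds shown leave open where compound 1, compound 2 and compound 3 each fall beneath that limit, and whether placing pyrrolidin-3-yl on the aromatic carbon changes the value in this assay at all.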